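A triazole gives way to an oxadiazole

The compounds below may be only part of what the source reports. "The series", "measured", "known", "first", "only" and "open" are said of these compounds alone.

In a functional assay on SH-SY5Y cells (Homo sapiens) for cytotoxicity, read by MTT assay, with a stated time of 56 h (a lower number here means that less compound is needed, a higher number that more compound is needed for the effect), compound 1 `O=C(CCCCCCCc1cc(-c2cccnc2)on1)Nc1ccccc1-c1ccccc1` gives 59.8 nM and compound 2 `O=C(CCCCCCCc1cc(-c2cccnc2)[nH]n1)Nc1ccccc1-c1ccccc1` gives 384 nM while compound 3 `O=C(CCCCCCCc1nnc(-c2cccnc2)[nH]1)Nc1ccccc1-c1ccccc1` gives 82.9 nM as its reading. Compound 3 thus sits within the scatter of compound 1 and clearly under compound 2. Compound 4 `O=C(CCCCCCCc1nnc(-c2cccnc2)o1)Nc1ccccc1-c1ccccc1` carries 5-(pyridin-3-yl)-1,3,4-oxadiazol-2-yl in place of 5-(pyridin-3-yl)-4H-1,2,4-triazol-3-yl on a saturated chain carbon (5-(pyridin-3-yl)-1,3,4-oxadiazol-2-yl in place of 5-(pyridin-3-yl)-4H-1,2,4-triazol-3-yl on a saturated chain carbon, seven bonds along the chain from a carbonyl carbon). Earlier swaps at this place gave a 1.4-fold higher number from compound 1 to compound 3 (0.14 log units; within the scatter) as a change within the scatter, whereas the modest 6.4-fold higher number from compound 1 to compound 2 (0.81 log units; beyond the scatter) and a 4.6-fold lower number from compound 2 to compound 3 (0.67 log units; beyond the scatter) go beyond it, and both involve compound 2. No step beyond the scatter is therefore expected, and the estimated change in this assay is small (a 1.0-fold lower number from compound 3 to compound 4 (0.02 log units; within the scatter)). Compound 4 is estimated at 80 nM (expected range 30 nM to 220 nM).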

Compound 4, half-maximal effective concentration: 370 nM
Estimate against measurement, compound 4: 4.6-fold (0.67 log units) below; the whole stated range lies below it.
By their numbers in this assay, from the lowest: compounds 1 and 3 (each within the scatter of the next); then compounds 4 and 2 (each within the scatter of the next).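

In this assay compound 2 no longer stands alone at this position: there is a 4.5-fold higher number from compound 3 to compound 4 (0.65 log units; beyond the scatter) and also a 6.2-fold higher number from compound 1 to compound 4 (0.79 log units; beyond the scatter) while a 1.0-fold lower number from compound 2 to compound 4 (0.02 log units; within the scatter) remains. Two five-membered rings, each carrying pyridin-3-yl, can therefore give clearly different numbers here, and the four readings fall into two pairs, compounds 1 and 3 and compounds 2 and 4. Going by these compounds, what stays open is how a longer chain, or an amine on the ring, would read at this place. No measurement at hand accounts for this split into pairs.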